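Swapping an ester-bearing phenyl for a fluoropyridine

This account rests on a few compounds, and the source may have more. Where it says the series, first, only, none or still open, it means among the compounds named here.

Compound 1 `CCS(=O)(=O)Nc1cc(-c2ccc3ncnc(Nc4cccc(C(=O)OC)c4)c3c2)cnc1OC`: 10100 nM
Compound 2 `CCS(=O)(=O)Nc1cc(-c2ccc3ncnc(Nc4ccc(C(=O)OC)c(OC)c4)c3c2)cnc1OC`: 10900 nM

In a functional assay on MCF7 cells (Homo sapiens) for cytotoxicity, read by sulforhodamine B assay, with a stated time of 72 h (on this read-out higher numbers stand for weaker inhibition and lower numbers for stronger inhibition), compound 1 gives 10100 nM and compound 2 gives 10900 nM. Among the measured compounds shown here, these are the only two numbers in hand, and the step of a 1.1-fold higher number from compound 1 to compound 2 (0.03 log units; within the scatter) lies within the scatter, so compound 2 cannot be told apart from compound 1 on this read-out. Compound 3 `CCS(=O)(=O)Nc1cc(-c2ccc3ncnc(Nc4ccc(F)nc4)c3c2)cnc1OC` differs from compound 2 by 6-fluoropyridin-3-yl in place of 3-methoxy-4-(methoxycarbonyl)phenyl on a nitrogen on an aromatic ring. For the measured compounds named here, the one measured step also altered the group on that same nitrogen, and it changed nothing beyond the scatter. Going by the values given here, no measured step removes the ester or brings in a ring with a nitrogen, so the size of this change has no direct precedent here. The step of a 1.1-fold lower number from compound 2 to compound 3 (0.04 log units; within the scatter) is therefore expected to stay within the scatter. Compound 3 is estimated at 10000 nM, with a range from 3000 nM to 40000 nM.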

Compound 3, half-maximal inhibitory concentration: 5390 nM
The estimate for compound 3 lay 1.9-fold (0.27 log units) above the measured number, within the range that was stated.
By their numbers in this assay, from the lowest: compounds 3, 1 and 2 (each within the scatter of the next, the first and the last beyond it).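

In this assay, the group on this nitrogen can move the number past the scatter: 6-fluoropyridin-3-yl in place of 3-methoxy-4-(methoxycarbonyl)phenyl gives a 2.0-fold lower number from compound 2 to compound 3 (0.31 log units; beyond the scatter), a modest step and the first here to exceed the scatter. Set against 3-(methoxycarbonyl)phenyl, the same ring gives a 1.9-fold lower number from compound 1 to compound 3 (0.27 log units; within the scatter), which stays within the scatter, so compound 1 goes against any rule that the fluoropyridine outperforms both ester-bearing groups. No supporting data bear on why the group swap produces this step.

The compounds shown leave open whether the fluorine or the ring nitrogen of the new group carries the step; a pyridin-3-yl group without fluorine and a fluorophenyl group on the same nitrogen would separate the two. From the compounds shown here alone, it also remains open how a carboxylic acid or an amine on the ring would behave here.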